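A Methoxy Analogue in a Series Without Measurable Activity

The source may report more compounds than this note shows. Statements on the series, on what has been measured and on what is new or still open speak of the compounds shown alone.

Measured compounds:
compound 1 `Cc1ccc(-c2cn(C/C=C3\OC(=O)C(OCc4ccccc4)=C3OCc3ccccc3)nn2)cc1`, > 100000 nM
compound 2 `O=C1O/C(=C\Cn2cc(-c3cc(F)cc(F)c3)nn2)C(OCc2ccccc2)=C1OCc1ccccc1`, "not active" (no number reported)
compound 3 `CCCCCc1ccc(-c2cn(C/C=C3\OC(=O)C(OCc4ccccc4)=C3OCc3ccccc3)nn2)cc1`, > 100000 nM

Of the compounds shown here, three sharing one core have been tested in a functional assay on CFPAC-1 cells (Homo sapiens) for antiproliferative activity, read by MTT assay, with a stated time of 72 h; on this read-out lower numbers stand for stronger inhibition and higher numbers for weaker inhibition. Compound 1 reaches only the limit of the assay, giving > 100000 nM. Compound 3 likewise reaches only the limit, at > 100000 nM. For compound 2 the result in this assay is recorded as "not active" (no number reported), with no number reported. The step that the two limits leave unreadable from compound 1 to compound 3 therefore cannot be read, because both of its ends sit at the limit of > 100000 nM in this assay, at which 2 of the 3 values shown sit. Compound 3 thus stands where every measured compound of the set stands: at the limit, with no number that would set it apart from the others.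

Compound 4 `COc1ccc(-c2cn(C/C=C3\OC(=O)C(OCc4ccccc4)=C3OCc3ccccc3)nn2)cc1` has not yet been measured. It differs from compound 3 in one place: methoxy in place of pentyl on an aromatic carbon. Within the data shown here, the single measured step offers no readable size, so the measured compounds give no ground to expect any movement off the limit for compound 4. Compound 4 is expected to give 150000 nM in this assay, between 40000 nM and 600000 nM. The expected step that the limit leaves unreadable from compound 3 to compound 4 is accordingly estimated as none beyond the scatter, most likely reported again only as a limit.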

Compound 4, half-maximal inhibitory concentration: > 100000 nM
Compound 4 was reported as a limit (the forecaster's own chance of this, stated with the estimate: 85%); the middle value does not contradict the limit.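

In this assay compound 4 gives > 100000 nM, which is a limit and not a number. No step from compound 1 or compound 3 to compound 4 can be read, because these compounds all sit at one limit: the limit of > 100000 nM in this assay, at which 3 of the 4 values shown sit.

The compounds shown leave open whether any group at this place on the shared core gives a measurable value in this assay.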